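The source may report more compounds than this note shows. Statements on the series, on what has been measured and on what is new or still open speak of the compounds shown alone.

Compound 1 `Cc1ccccc1C(=O)Nc1ccc(S(=O)(=O)NC2CCN(C(=O)CN)CC2)c2ccccc12` gives 4.1 nM in an assay on L1.2 cells for binding affinity to C-C chemokine receptor type 8 (Homo sapiens); on this read-out higher numbers stand for weaker inhibition and lower numbers for stronger inhibition. Compound 2 `CCCNC(=O)N1CCC(NS(=O)(=O)c2ccc(NC(=O)c3ccccc3C)c3ccccc23)CC1` gives 77.4 nM in this assay, the higher of the two numbers; the step of a 19-fold higher number from compound 1 to compound 2 (1.28 log units; beyond the scatter) is the only measured one. Compound 3 `CCCC(=O)N1CCC(NS(=O)(=O)c2ccc(NC(=O)c3ccccc3C)c3ccccc23)C1` carries 1-(propylcarbonyl)pyrrolidin-3-yl in place of 1-(propylcarbamoyl)piperidin-4-yl on a sulfonamide nitrogen. The measured step concerns a different group, so no shown step bears directly on this change; the expectation is a number near compound 2 with wide uncertainty. For compound 3 the estimate is 80 nM (range 20 nM to 400 nM), a step of a 1.0-fold higher number from compound 2 to compound 3 (0.01 log units; within the scatter) expected from compound 2.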

Compound 3, inhibition constant: 34.3 nM
The estimate for compound 3 lay 2.3-fold (0.37 log units) above the measured number, within the range that was stated.
By their numbers in this assay, from the lowest: compound 1; then compound 3; then compound 2.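

On the sulfonamide nitrogen, 1-(propylcarbonyl)pyrrolidin-3-yl is tolerated in place of 1-(propylcarbamoyl)piperidin-4-yl, and the number improves modestly (a 2.3-fold lower number from compound 2 to compound 3 (0.35 log units; beyond the scatter)). The change still leaves compound 3 short of compound 1, which carries 1-((aminomethyl)carbonyl)piperidin-4-yl (an 8.4-fold higher number from compound 1 to compound 3 (0.92 log units; beyond the scatter)). No supporting measurement explains either step.

The step from compound 2 combines a change of ring size with a change from propylcarbamoyl to propylcarbonyl, and these compounds cannot separate the two. Also open, going by these compounds, is how 1-((aminomethyl)carbonyl)pyrrolidin-3-yl would read, joining the five-membered ring to the primary amine.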